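Ring Size at the Thiocarbonyl Carbon Across Two Cores

A few compounds are considered here, and "the series" means these few. Any claim that something is new, unique, unknown or untested is made for them only; others in the source may bear on it.

Compound 1 `Cc1cccc(/C(N)=N/NC(=S)N2CCCCC2)n1` and compound 2 `Cc1cccc(/C(N)=N/NC(=S)N2CCCC2)n1` share one core and differ only on a thiocarbonyl carbon. In a functional assay on A-431 cells (Homo sapiens) for cytotoxicity, read by MTT assay, with a stated time of 72 h (a lower number here means a stronger inhibitor, a higher number a weaker inhibitor), compound 1 gives 12400 nM, and compound 2 gives 4000 nM. The change between them is pyrrolidin-1-yl in place of piperidin-1-yl on a thiocarbonyl carbon, and it made a 3.1-fold lower number from compound 1 to compound 2 (0.49 log units; beyond the scatter). Compound 3 `Cc1ccnc(/C(N)=N/NC(=S)N2CCCCC2)c1` has the same atoms as compound 1, joined differently; the difference between the two cores is not broken down here. In this assay compound 3 gives 18900 nM. Compound 4 `Cc1ccnc(/C(N)=N/NC(=S)N2CCCC2)c1` is not yet measured; it differs from compound 3 by pyrrolidin-1-yl in place of piperidin-1-yl on a thiocarbonyl carbon, the same change as that from compound 1 to compound 2, at a place described in the same words. Because a 3.1-fold lower number from compound 1 to compound 2 (0.49 log units; beyond the scatter) lay beyond the scatter, a step of similar size is expected here, namely a 3.1-fold lower number from compound 3 to compound 4 (0.49 log units; beyond the scatter). Compound 4 is accordingly estimated at 6100 nM, with a likely range from 2500 nM to 15000 nM.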

Compound 4, half-maximal inhibitory concentration: 900 nM
Compound 4: the middle estimate sits 6.8-fold (0.83 log units) above what was measured, outside the stated range (below it).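

In this assay, pyrrolidin-1-yl in place of piperidin-1-yl on a thiocarbonyl carbon gave a 21-fold lower number from compound 3 to compound 4 (1.32 log units; beyond the scatter). The direction of the change carried over from one core to the other, but its size did not: the same change on two cores in this assay, a 3.1-fold lower number (0.49 log units; beyond the scatter) from compound 1 to compound 2 and a 21-fold lower number (1.32 log units; beyond the scatter) from compound 3 to compound 4, 6.8-fold (0.83 log units) apart, beyond the scatter of two such steps. The step measured on one core therefore gave the sign of the step on the other but did not fix its size, and two pairs do not show why the cores differ or how the change would behave on a further core.

The compounds shown leave open whether a morpholin-4-yl or an azepan-1-yl group on the same thiocarbonyl carbon would follow the same direction. As far as these compounds go, it also remains open whether an open-chain dimethylamino group would show the same difference between the two cores.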